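Swapping an aryl group for an amide on the shared core

The source may report more compounds than this note shows. Statements on the series, on what has been measured and on what is new or still open speak of the compounds shown alone.

Of the compounds shown here, three with a common core have been measured in an assay (Rattus norvegicus) for inhibition of Fatty-acid amide hydrolase 1 (Homo sapiens); on this read-out higher numbers stand for weaker inhibition and lower numbers for stronger inhibition. Compound 1, `COC(=O)c1ccccc1-c1cnc(C(=O)CCCCCCc2ccccc2)o1`, gives 60 nM. Compound 2, `COC(=O)c1cccc(-c2cnc(C(=O)CCCCCCc3ccccc3)o2)c1`, gives 12 nM. Compound 3, `O=C(CCCCCCc1ccccc1)c1ncc(-c2ccc(F)cc2)o1`, gives 62 nM, which is the highest of the three numbers; compound 1 sits at a value within the scatter of compound 3, while compound 2 lies beyond the scatter at a clearly lower number, so among these three only compound 2 is set apart from compound 3.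

Compound 4, `O=C(CCCCCCc1ccccc1)c1ncc(C(=O)N2CCSCC2)o1`, has not been measured. Relative to compound 3 the difference is (thiomorpholin-4-yl)carbonyl in place of 4-fluorophenyl on an aromatic carbon. Among the measured compounds shown here, no measured pair in this set shows a step of this kind, so the expected size rests on the spread already seen across compounds 1, 2 and 3. The step is expected to be small, with no clear direction beyond the scatter: the estimate means a step of a 1.4-fold lower number from compound 3 to compound 4 (0.14 log units; within the scatter). Compound 4 is therefore expected to give about 45 nM in this assay, within a range from 12 nM to 180 nM.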

Compound 4, inhibition constant: 10 nM
The estimate for compound 4 lay 4.5-fold (0.65 log units) above the measured number; measured number outside the range, below it.
By their numbers in this assay, from the lowest: compounds 4 and 2 (each within the scatter of the next); then compounds 1 and 3 (each within the scatter of the next).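

In this assay, putting (thiomorpholin-4-yl)carbonyl in place of 4-fluorophenyl on the aromatic carbon next to the ring oxygen gives a 6.2-fold lower number from compound 3 to compound 4 (0.79 log units; beyond the scatter) and so marks a real gain in inhibition. Compounds 1, 2 and 3 all carry a six-membered aromatic ring of carbon only at this place, so they could not show that a non-aromatic ring joined through a carbonyl is accepted here, and even goes with stronger inhibition than the 4-fluorophenyl group. No measurement at hand says which part of the entering group accounts for this step. On these data alone, it remains open whether the ring sulfur matters, which a morpholine amide, with oxygen in its place, or a piperidine amide, with carbon, would test. As far as these compounds go, it is also open whether the ring is needed at all, a question for a simple dimethylamide or a carboxylic acid on the same carbon.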